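The compounds below may be only part of what the source reports. "The series", "measured", "known", "first", "only" and "open" are said of these compounds alone.

Of the compounds shown here, three built on one shared core have been measured in a functional assay on NCI/ADR-RES cells (Homo sapiens) for inhibition, read by sulforhodamine B assay, with a stated time of 48 h, tested at 0.01 uM; on this read-out higher numbers stand for a weaker effect at the one concentration tested and lower numbers for a stronger effect. Compound 1 `O=C(Nc1cccc(-n2cc(-c3ccncc3)c(-c3cc(O)cc(Cl)c3)n2)c1)Nc1ccc(Cl)c(C(F)(F)F)c1` gives 96%. Among the compounds with values here, compound 2 `O=C(Nc1cccc(-n2cc(-c3ccncc3)c(-c3cc(O)cc(Cl)c3)n2)c1)Nc1ccc(Cl)c(Cl)c1` gives 109%, and the single-point step a number 13 percentage points higher from compound 1 to compound 2 (beyond the scatter) is the only such step recorded so far. Compound 3 `COc1cc(Cl)cc(-c2nn(-c3cccc(NC(=O)Nc4cc(C(F)(F)F)cc(C(F)(F)F)c4)c3)cc2-c2ccncc2)c1` gives 99%. Compound 2 stands at the top of the three numbers shown, though its distance to compound 3 lies within the scatter, while its distance to compound 1 lies beyond it. None of the three numbers points to a strong effect at the one concentration tested.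

Compound 4 `COc1cc(Cl)cc(-c2nn(-c3cccc(NC(=O)Nc4ccc(Cl)c(Cl)c4)c3)cc2-c2ccncc2)c1` has not yet been measured. It differs from compound 2 by methyl in place of hydrogen on an oxygen on an aromatic ring, that is, hydroxy to methoxy. Within the data shown here, no measured step touches this place: the one recorded step, a number 13 percentage points higher from compound 1 to compound 2 (beyond the scatter), concerns a different part of the molecule. Compound 3 carries methoxy as compound 4 does, but also a different urea aryl group, so its value and that of compound 2 show only that the two lie within the scatter of each other. With all three numbers near the top of the scale, compound 4 is expected to show no step beyond the scatter, a number 6 percentage points lower from compound 2 to compound 4 (within the scatter). Compound 4 is therefore estimated at 103%, between 88% and 118%.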

Compound 4, a percentage reported as activity, at one concentration (the size of the read-out at that concentration, not a potency): 97%
Compound 4: middle estimate off by 6 percentage points, on the high side, within the range that was stated.
By their numbers in this assay, from the lowest: compounds 1, 4, 3 and 2 (each within the scatter of the next, the first and the last beyond it).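

Within the data shown here, the change from hydroxy to methoxy, with methyl entering on an oxygen on an aromatic ring, is read directly in this assay for the first time: a number 12 percentage points lower from compound 2 to compound 4 (beyond the scatter) in the direction of a stronger effect at the one concentration tested. The only earlier step lay at the urea aryl group, a number 13 percentage points higher from compound 1 to compound 2 (beyond the scatter) in the opposite direction, so each of these two places is now shown to move the number by a modest amount, and compound 4 at 97% still shows no strong effect. Nothing in the data gives a measured property that could account for this step.

Among these compounds, this single pair leaves open whether the same change would give a similar step on another urea aryl group, such as the one carried by compound 1 or compound 3. Also open is how an ethoxy group or a longer chain on the same oxygen, or an amine or a carboxylic acid in place of the hydroxy, would read, and whether any of them would bring the number far below those of the four compounds shown.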